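The source may report more compounds than this note shows. Statements on the series, on what has been measured and on what is new or still open speak of the compounds shown alone.

In a functional assay on KB cells (Homo sapiens) for cytotoxicity (a lower number here means a stronger inhibitor, a higher number a weaker inhibitor), compound 1 (`COc1ccc(S(=O)(=O)N2CCc3cccc(NC(=O)c4cccs4)c32)cc1`) gives 43 nM, compound 2 (`COc1ccc(S(=O)(=O)N2CCc3cccc(NC(=O)c4ccc([N+](=O)[O-])cc4)c32)cc1`) gives 95 nM and compound 3 (`COc1ccc(S(=O)(=O)N2CCc3cccc(NC(=O)c4ccc(F)cc4)c32)cc1`) gives 85 nM. Compound 3 lies within the scatter of both others, with a 2.0-fold higher number from compound 1 to compound 3 (0.30 log units; within the scatter) and a 1.1-fold lower number from compound 2 to compound 3 (0.05 log units; within the scatter). Compound 4 (`COc1ccc(S(=O)(=O)N2CCc3cccc(NC(=O)c4ccncc4)c32)cc1`) has pyridin-4-yl in place of 4-fluorophenyl on a carbonyl carbon. The measured steps that bear on this change alter the group at that same place. The largest, a 2.2-fold higher number from compound 1 to compound 2 (0.34 log units; beyond the scatter), is modest, so no step beyond the scatter is expected in this assay. The expected change is a 1.1-fold higher number from compound 3 to compound 4 (0.02 log units; within the scatter). For compound 4 the estimated value is 90 nM, with an expected range from 35 nM to 230 nM.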

Compound 4, half-maximal inhibitory concentration: 8.9 nM
For compound 4 the middle estimate is 10-fold (1.00 log units) above the measured one, and the stated range ends above it.
By their numbers in this assay, from the lowest: compound 4; then compounds 1, 3 and 2 (each within the scatter of the next, the first and the last beyond it).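

Swapping the group on the carbonyl carbon for pyridin-4-yl gives a 9.6-fold lower number from compound 3 to compound 4 (0.98 log units; beyond the scatter) and an 11-fold lower number from compound 2 to compound 4 (1.03 log units; beyond the scatter) and a 4.8-fold lower number from compound 1 to compound 4 (0.68 log units; beyond the scatter) in this assay with all three beyond the scatter. This place can therefore move the number much further than the steps among thiophen-2-yl, 4-nitrophenyl and 4-fluorophenyl had shown, and compound 4 has the lowest number of the four. No measurement at hand gives a reason for this drop. On these data alone, what pyridin-3-yl or a 4-aminophenyl group would give at this place stays open, as does whether the drop holds on other cells.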